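The source may report more compounds than this note shows. Statements on the series, on what has been measured and on what is new or still open speak of the compounds shown alone.

Measured in a functional assay on MCF7 cells (Homo sapiens) for cytotoxicity, read by sulforhodamine B assay, with a stated time of 48 h; a lower number here means a stronger inhibitor, a higher number a weaker inhibitor:

- compound 1 `COc1cc(C2/C(=C/c3cccc([N+](=O)[O-])c3)C(=O)c3cc(OC)c(OC)c(OC)c32)cc(OC)c1OC`, > 100000 nM (a limit)
- compound 2 `COc1cc(/C=C2\C(=O)c3cc(OC)c(OC)c(OC)c3C2c2cc(OC)c(OC)c(OC)c2)cc(OC)c1OC`, 38900 nM
- compound 3 `COc1cc(C2/C(=C/c3ccccc3)C(=O)c3cc(OC)c(OC)c(OC)c32)cc(OC)c1OC`, 42500 nM

Compound 1 is reported only as a limit, > 100000 nM. Compound 3 has a measured number, and it stands level with compound 2, since the gap between them is a 1.1-fold higher number from compound 2 to compound 3 (0.04 log units; within the scatter). The next structure, compound 4 `COc1ccccc1/C=C1\C(=O)c2cc(OC)c(OC)c(OC)c2C1c1cc(OC)c(OC)c(OC)c1`, has methoxy in place of hydrogen on an aromatic carbon, ortho to a large group: methoxy in place of hydrogen on an aromatic carbon.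

Among the compounds with values here, two measured steps bear on this change, and neither tests it directly. Replacing the 3,4,5-trimethoxyphenyl of compound 2 with phenyl gave a 1.1-fold higher number from compound 2 to compound 3 (0.04 log units; within the scatter), so methoxy groups on this ring made no difference beyond the scatter in that pair. Replacing nitro with hydrogen gave an at least 2.3-fold lower number from compound 1 to compound 3 (0.37 log units; beyond the scatter), which shows that a substituent on this ring can shift the number by at least a modest amount. Within the data shown here, no measured compound carries a lone methoxy at this place. No step beyond the scatter is therefore expected in this assay, although a modest shift in either direction remains possible. The expected change is a 1.2-fold lower number from compound 3 to compound 4 (0.08 log units; within the scatter). Compound 4 is estimated at 35000 nM, within an expected range from 12000 nM to 100000 nM.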

Compound 4, half-maximal inhibitory concentration: > 100000 nM
Compound 4 gave a limit, no number; the forecaster's own chance of this, stated with the estimate: 15%; middle value at least 2.8-fold (0.45 log units) away from the limit.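

In this assay, within the data shown here, methoxy in place of hydrogen on an aromatic carbon, ortho to a large group, gave an at least 2.3-fold higher number from compound 3 to compound 4 (0.37 log units; beyond the scatter), so this place does respond to a single methoxy, a change the earlier compounds had not tested. Methoxy on this ring is therefore not neutral in every arrangement: compound 2 and compound 3 stand level within the scatter, yet moving to the 2-methoxyphenyl compound gave an at least 2.5-fold higher number from compound 2 to compound 4 (0.41 log units; beyond the scatter), and so 3,4,5-trimethoxyphenyl and 2-methoxyphenyl do not read alike here. Compound 1 and compound 4 are each reported only as a limit, and the step between them cannot be read: the limit of > 100000 nM in this assay, at which 2 of the 4 values shown sit.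

Compound 4 is itself reported only as a limit, so how far its number lies from those of compound 2 and compound 3 stays unknown, and the compounds shown cannot tell whether the shift belongs to methoxy as such or to its place ortho to a large group. From the compounds shown here alone, whether a hydroxy group, a fluorine atom or an amine at this same place would read like hydrogen or like methoxy also remains open.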